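This account rests on a few compounds, and the source may have more. Where it says the series, first, only, none or still open, it means among the compounds named here.

Measured compounds:
- compound 1 `CCn1c(-c2cnc(C)nc2)nc2c(N[C@H]3CCN(C(=O)C4CCC4)C3)ncnc21`: 9.2 L/kg
- compound 2 `CCn1c(-c2ccc(C(F)(F)F)nc2)nc2c(O[C@H]3CCN(C(=O)[C@H]4C[C@@H](OC)C4)C3)ncnc21`: 1.3 L/kg
- compound 3 `CCn1c(-c2cnc(C)nc2)nc2c(O[C@H]3CCN(C(=O)C4CCOC4)C3)ncnc21`: 0.9 L/kg

Of the compounds shown here, three sharing one core have been tested in an ADME assay (Rattus norvegicus, strain Wistar Han) for pharmacokinetics; a lower number here means that more of the compound stays in the plasma, a higher number that more of the compound sits outside the plasma. Compound 1 gives the highest of the three numbers; compound 2 sits well below it, and compound 3 lower still, both gaps clearly beyond the usual scatter. Among the measured compounds shown here, because no pair of these three differs in a single place, their gaps cannot be tied to one change, and they are taken only as a spread of values.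

Compound 4 `CCn1c(-c2cnc(C)nc2)nc2c(N[C@H]3CCN(C(=O)C4CCOCC4)C3)ncnc21` is the next compound, and it differs from compound 1 in one place: oxan-4-yl in place of cyclobutyl on a carbonyl carbon. The amide attached to the ring nitrogen changes from a cyclobutylcarbonyl to a (oxan-4-yl)carbonyl; everything else is unchanged.

Since compound 1 stands so far above compound 2 and compound 3 in this assay, a fall is the more likely direction, though a small change within the scatter would not surprise. The expected step from compound 1 to compound 4 is a 1.8-fold lower number from compound 1 to compound 4 (0.26 log units; within the scatter). Compound 4 is therefore expected to give about 5 L/kg in this assay, within a range of 2.5 L/kg to 10 L/kg.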

Compound 4, volume of distribution: 4.3 L/kg
For compound 4 the middle estimate is 1.2-fold (0.07 log units) above the measured one, and the stated range covers the measured number.
By their numbers in this assay, from the lowest: compounds 3 and 2 (each within the scatter of the next); then compound 4; then compound 1.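

In this assay, among the compounds shown here, this is the first change that can be read on its own: with the rest of the molecule held fixed, oxan-4-yl in place of cyclobutyl on the carbonyl carbon gives a 2.1-fold lower number from compound 1 to compound 4 (0.33 log units; beyond the scatter). The step is modest but beyond the scatter, so the group on this carbonyl carbon does affect the read-out, and the direction is a fall. No supporting measurement accounts for this shift.

The entering group differs from the leaving one both in ring size and in carrying a ring oxygen, so this single step cannot separate the two. Cyclohexyl on the same carbonyl carbon would keep the larger ring without the oxygen, and piperidin-4-yl would put a ring amine there, so what either would give remains open.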